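Moving the Trifluoromethyl Group Around the Aromatic Ring

This account rests on a few compounds, and the source may have more. Where it says the series, first, only, none or still open, it means among the compounds named here.

Compound 1 `O=C1c2ccccc2S(=O)(=O)N1CCCCCCN1CCN(c2ccccc2Cl)CC1` and compound 2 `O=C1c2ccccc2S(=O)(=O)N1CCCCCCN1CCN(c2ccccc2C(F)(F)F)CC1` share one core and differ only in the group on the aromatic ring. In an ADME assay on HEK293 cells for displacement of a labelled ligand from 5-hydroxytryptamine receptor 6 (Homo sapiens), read by radioligand binding, with a stated time of 1 h (on this read-out higher numbers stand for weaker inhibition and lower numbers for stronger inhibition), compound 1 gives 459 nM, while compound 2 gives 1270 nM. Going by the values given here, the single measured step, a 2.8-fold higher number from compound 1 to compound 2 (0.44 log units; beyond the scatter), is the only comparison in hand, and it leaves compound 2 with the highest of the two numbers. Compound 3 `O=C1c2ccccc2S(=O)(=O)N1CCCCCCN1CCN(c2cccc(C(F)(F)F)c2)CC1` is not yet measured; it keeps the same atoms and changes (3-(trifluoromethyl)phenyl in place of 2-(trifluoromethyl)phenyl on an amine nitrogen in a ring). Among the compounds with values here, no measured step shows what moving a group to another place on the aromatic ring does here: the one known step swaps one group for another at the same place, so it does not bear on this change. The step of a 1.2-fold lower number from compound 2 to compound 3 (0.06 log units; within the scatter) is therefore expected to stay within the scatter of this assay, with wide uncertainty. Compound 3 is estimated at 1100 nM in this assay, between 300 nM and 4000 nM.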

Compound 3, inhibition constant: 52 nM
Compound 3: middle estimate off by 21-fold (1.33 log units), on the high side; the measured number lies below the stated range.
By their numbers in this assay, from the lowest: compound 3; then compound 1; then compound 2.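

In this assay, going by these compounds alone, the place of the trifluoromethyl group on the aromatic ring matters far more than the one earlier step could show: a 24-fold lower number from compound 2 to compound 3 (1.39 log units; beyond the scatter) follows from 3-(trifluoromethyl)phenyl in place of 2-(trifluoromethyl)phenyl, a change that keeps the same atoms. The earlier step made trifluoromethyl look worse than chloro, yet that reading holds only for the 2-substituted pair, since the new comparison gives an 8.8-fold lower number from compound 1 to compound 3 (0.95 log units; beyond the scatter), and compound 3 now has the lowest number of the three. Nothing at hand explains why this move has so large an effect.

As far as these compounds go, whether a methoxy group or a nitrile in place of the trifluoromethyl group of compound 3 would keep so low a number remains open. So does the effect of a shorter chain on the shared core.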